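The source may report more compounds than this note shows. Statements on the series, on what has been measured and on what is new or still open speak of the compounds shown alone.

Measured so far in a functional assay on BXPC-3 cells (Homo sapiens) for cytotoxicity, read by fluorescence, with a stated time of 48 h; a lower number here means that less compound is needed, a higher number that more compound is needed for the effect
compound 1 `CC(C)=CCC/C(C)=C/CC/C(C)=C/CSC[C@H](NC(=O)CCCCCN1CCCC1)C(=O)NC1CCCCC1` gives 12700 nM
compound 2 `CC(C)=CCC/C(C)=C/CC/C(C)=C/CSC[C@H](NC(=O)CCCCCN1CCN(C)CC1)C(=O)NC1CC1` gives 6300 nM
compound 3 `CC(C)=CCC/C(C)=C/CC/C(C)=C/CSC[C@H](NC(=O)CCCCCN1CCN(C)CC1)C(=O)N1CCCC1` gives 3200 nM

Compound 1 stands at the high end of these numbers. Its value lies within the scatter of the value of compound 2, while the gap between compound 1 at 12700 nM and compound 3 at 3200 nM lies beyond the scatter.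

Compound 4 `CC(C)=CCC/C(C)=C/CC/C(C)=C/CSC[C@H](NC(=O)CCCCCN1CCCC1)C(=O)NC1CCCCCCC1` is not yet measured and differs from compound 1 in one place. The change is cyclooctyl in place of cyclohexyl on an amide-type nitrogen, counted as cyclooctyl in place of cyclohexyl on an amide-type nitrogen in full.

For the measured compounds named here, no measured step covers this ring change. Going by the values given here, the only step that bears on it is a 2.0-fold lower number from compound 2 to compound 3 (0.29 log units; within the scatter) for pyrrolidin-1-yl in place of cyclopropylamino on a carbonyl carbon. As far as these compounds go, this is thin support from a single pair, so no step beyond the scatter is expected in this assay and the direction stays open. The expected step is a 1.3-fold lower number from compound 1 to compound 4 (0.10 log units; within the scatter) as an estimate only. Compound 4 is estimated at 10000 nM with an expected range of 4000 nM to 25000 nM as its bounds.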

Compound 4, half-maximal effective concentration: 4000 nM
Estimate against measurement, compound 4: 2.5-fold (0.40 log units) above; the range from low to high includes it.
By their numbers in this assay, from the lowest: compounds 3, 4, 2 and 1 (each within the scatter of the next, the first and the last beyond it).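

In this assay, for the compounds shown here, the group on the amide-type nitrogen gives the only single-place step so far that lies beyond the scatter: cyclooctyl in place of cyclohexyl gives a 3.2-fold lower number from compound 1 to compound 4 (0.50 log units; beyond the scatter). The only earlier step, a 2.0-fold lower number from compound 2 to compound 3 (0.29 log units; within the scatter), lay within the scatter, so this position is the first shown to move the number, with the rest of compound 1 left unchanged. This rests on one pair, and no data at hand account for the step.

A cycloheptyl or cyclopentyl group, or an open n-octyl chain, on the same nitrogen would show whether the number follows ring size or is particular to cyclooctyl. Also open, as far as these compounds go, is whether cyclooctyl acts the same way with the amine end carried by compound 2 and compound 3.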